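Terminal carboxy on the decyl chain: expected cytotoxicity

The compounds below may be only part of what the source reports. "The series", "measured", "known", "first", "only" and "open" are said of these compounds alone.

Measured compounds:
- Compound 1, `CCCCCCCCCCNC(=O)C1C(C(=O)O)[C@@H]2CC[C@H]1O2`: 10000 nM
- Compound 2, `CCOC(=O)c1cn[nH]c1NC(=O)C1C(C(=O)O)[C@@H]2CC[C@H]1O2`: 10000 nM
- Compound 3, `O=C(O)c1ccc(NC(=O)C2C(C(=O)O)[C@@H]3CC[C@H]2O3)cc1Cl`: 10000 nM

All three share the same bicyclic core carrying an amide and a carboxylic acid; they differ only in the group attached to the amide nitrogen. In an ADME assay on SJ-G2 cells (Homo sapiens) for cytotoxicity, read by MTT assay, with a stated time of 72 h (on this read-out higher numbers stand for weaker inhibition of growth and lower numbers for stronger inhibition of growth), compound 1 gives 10000 nM. Compound 2 gives 10000 nM and compound 3 gives 10000 nM, so the three values sit level with one another, and the differences among them lie within the usual scatter. Nothing in these numbers separates a long saturated chain from a substituted ring on the amide nitrogen.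

Compound 4, `O=C(O)CCCCCCCNC(=O)C1C(C(=O)O)[C@@H]2CC[C@H]1O2`, has not yet been measured. It differs from compound 1 by a single change: carboxy in place of propyl on a saturated chain carbon, seven bonds along the chain from an amide-type nitrogen.

Because compound 1 gives 10000 nM and compounds 2 and 3 sit at the same level, the step of no change at the digits printed from compound 1 to compound 4 (within the scatter) is expected to stay within the scatter, with no shift in either direction that the assay could resolve. Compound 4 is therefore estimated at 10000 nM, with a range from 5000 nM to 20000 nM.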

Compound 4, concentration for 50% growth inhibition: 10000 nM
The estimate for compound 4 equals the measured number at the digits printed; the range from low to high includes it.
By their numbers in this assay, from the lowest: compounds 1, 2, 3 and 4 (each within the scatter of the next).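

Within the data shown here, compounds 1 and 4 form the first pair here that differs in only one place, so the effect of a single change can be read directly rather than inferred from compounds that differ more widely. In this assay putting carboxy in place of propyl on a saturated chain carbon, seven bonds along the chain from an amide-type nitrogen, gives no change at the digits printed from compound 1 to compound 4 (within the scatter) and so leaves the read-out unmoved. Among these compounds, this swap replaces an all-carbon end of the decyl chain with a group that adds a hydrogen-bond donor and a hydrogen-bond acceptor, and at this position the change produces no step that the measurement can resolve. Nothing measured here accounts for this flat result. The compounds shown leave open whether an amine, a hydroxyl group or an ethyl ester at this same place would move the number away from that of compound 1, and whether a shorter or longer chain carrying the carboxy would do so; they also leave open what a methyl ester in place of the carboxylic acid on the shared core would do.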